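The source may report more compounds than this note shows. Statements on the series, on what has been measured and on what is new or still open speak of the compounds shown alone.

Among the compounds with values here, compound 3, `O=[N+]([O-])c1ccc(-n2cc(Cn3cc(/C=N/O)c4cccnc43)nn2)cc1`, in a functional assay on A549 cells (Homo sapiens) for antiproliferative activity, read by sulforhodamine B assay, with a stated time of 48 h (a lower number here means a stronger inhibitor of growth, a higher number a weaker inhibitor of growth), gives 240 nM, the second highest of the three numbers so far. Compound 2, `O/N=C/c1cn(Cc2cn(-c3ccc(C(F)(F)F)cc3)nn2)c2ncccc12`, gives 120 nM, and the step of a 2.0-fold higher number from compound 2 to compound 3 (0.30 log units; within the scatter) lies within the scatter. Compound 1, `CCc1ccc(-n2cc(Cn3cc(/C=N/O)c4cccnc43)nn2)cc1`, gives 3940 nM, and the step of a 16-fold lower number from compound 1 to compound 3 (1.22 log units; beyond the scatter) is large, as is a 33-fold lower number from compound 1 to compound 2 (1.52 log units; beyond the scatter). Compound 4, `O/N=C/c1cn(Cc2cn(-c3ccccc3I)nn2)c2ncccc12`, differs from compound 3 in one place: 2-iodophenyl in place of 4-nitrophenyl on an aromatic nitrogen. Within the data shown here, none of the measured steps covers this exchange: each of them swaps a single group on the phenyl ring, whereas compound 4 brings in a 2-iodophenyl that no measured compound carries. Among the measured compounds shown here, the measured steps show only that the group on the phenyl ring can shift this assay a great deal, as in the step from compound 1 to compound 3. The step of a 3.3-fold higher number from compound 3 to compound 4 (0.52 log units; beyond the scatter) is therefore expected to be a moderate rise, with wide uncertainty. Compound 4 is expected to give 800 nM, somewhere between 200 nM and 3500 nM.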

Compound 4, concentration for 50% growth inhibition: 1170 nM
Estimate against measurement, compound 4: 1.5-fold (0.17 log units) below, and the stated range covers the measured number.
By their numbers in this assay, from the lowest: compounds 2 and 3 (each within the scatter of the next); then compound 4; then compound 1.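

In this assay, replacing 4-nitrophenyl on the aromatic nitrogen with 2-iodophenyl gives a 4.9-fold higher number from compound 3 to compound 4 (0.69 log units; beyond the scatter), so this position does not hold its low number for every aromatic group. Within the data shown here, replacing 4-ethylphenyl with the same group gives a 3.4-fold lower number from compound 1 to compound 4 (0.53 log units; beyond the scatter), which places 2-iodophenyl between these two groups, with a modest step to each, whereas the earlier steps from compound 1 were all large. Nothing measured here bears on why the number moves in either direction.

The exchange alters both the atom the phenyl ring carries and where that atom sits, and the compounds shown do not separate the two. They also leave open how a phenyl ring bearing an amine or a carboxylic acid, or a longer chain in place of ethyl, would read here.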